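The source may hold more compounds than are shown below. What is called first, only, known or untested is meant among the compounds shown, and "the series" means these compounds.

Working notes on the series. In a functional assay on MOLT-3 cells (Homo sapiens) for cytotoxicity, read by XTT assay, with a stated time of 48 h (on this read-out higher numbers stand for weaker inhibition and lower numbers for stronger inhibition), compound 1 `COc1ccc(/C=C/C(=O)c2cccc(-n3cc(COc4ccc5ccc(=O)oc5c4)nn3)c2)cc1OC` gives 3120 nM, compound 2 `COc1cc(/C=C/C(=O)c2ccc(-n3cc(COc4ccc5ccc(=O)oc5c4)nn3)cc2)cc(OC)c1OC` gives 79500 nM, and compound 3 `COc1ccc(/C=C/C(=O)c2cccc(-n3cc(COc4cc(=O)oc5ccccc45)nn3)c2)cc1OC` gives 3910 nM. Compound 3 thus sits level with compound 1, with a far lower number than compound 2. Compound 4 `COc1ccc(/C=C/C(=O)c2cccc(-n3cc(COc4cc(=O)oc5ccccc45)nn3)c2)c(OC)c1OC` has methoxy in place of hydrogen on an aromatic carbon, 3,4-dimethoxyphenyl to 2,3,4-trimethoxyphenyl (methoxy in place of hydrogen on an aromatic carbon). Within the data shown here, the one measured step, a 1.3-fold higher number from compound 1 to compound 3 (0.10 log units; within the scatter), concerns a different group and leaves this methoxy untested. Compound 2, a trimethoxyphenyl compound at 79500 nM, differs from compound 3 in more than one place, so it is only a weak hint towards a higher number. A small rise, hardly beyond the scatter, is expected: a 1.4-fold higher number from compound 3 to compound 4 (0.15 log units; within the scatter). Compound 4 is estimated at 5500 nM, with an expected range of 1700 nM to 20000 nM.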

Compound 4, half-maximal inhibitory concentration: 1130 nM
For compound 4 the middle estimate is 4.9-fold (0.69 log units) above the measured one; measured number below the stated range.
By their numbers in this assay, from the lowest: compound 4; then compounds 1 and 3 (each within the scatter of the next); then compound 2.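

In this assay, the ring of compound 3 takes a further methoxy on the aromatic carbon ortho to a large group and ortho to a methoxy group, and the number falls, a 3.5-fold lower number from compound 3 to compound 4 (0.54 log units; beyond the scatter). Among these compounds, this is the first measured step on the 3,4-dimethoxyphenyl end, and it shows that this position accepts methoxy, with 2,3,4-trimethoxyphenyl giving the lower number. No measurement on hand bears on a cause for this step.

Open, going by these compounds, is whether a hydroxyl, an amine or a longer ethoxy chain on this same carbon would also lower the number. Also open, on these data alone, is whether the same methoxy change would carry over to the core of compound 1.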